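The source may hold more compounds than are shown below. What is called first, only, known or untested is meant among the compounds shown, and "the series" means these compounds.

Three compounds share the core shown in compound 1 `CCN1CCN(c2cccc3c2CN([C@H](CCCNCc2cccs2)c2ccc(OC)c(OC)c2)C3=O)CC1` and differ only at one place on the chain. In a functional assay on RMS13 cells for antagonist activity at Urotensin-2 receptor (Homo sapiens), read by FLIPR and calcium flux, with a stated time of 1 h (on this read-out higher numbers stand for weaker inhibition and lower numbers for stronger inhibition), compound 1 gives 59 nM, compound 2 `CCN1CCN(c2cccc3c2CN([C@H](CCCNC(=O)c2cccs2)c2ccc(OC)c(OC)c2)C3=O)CC1` gives 140 nM and compound 3 `CCN1CCN(c2cccc3c2CN([C@H](CCCN(C)S(=O)(=O)c2cccs2)c2ccc(OC)c(OC)c2)C3=O)CC1` gives 88 nM. Compound 3 stands second highest of the three numbers, with a 1.5-fold higher number from compound 1 to compound 3 (0.17 log units; within the scatter) and a 1.6-fold lower number from compound 2 to compound 3 (0.20 log units; within the scatter) both within the scatter; only a 2.4-fold higher number from compound 1 to compound 2 (0.38 log units; beyond the scatter) lies beyond it. Compound 4 `CCN1CCN(c2cccc3c2CN([C@H](CCCNc2cncc(OC)n2)c2ccc(OC)c(OC)c2)C3=O)CC1` carries (6-methoxypyrazin-2-yl)amino in place of methyl((thiophen-2-yl)sulfonyl)amino on a saturated chain carbon, four bonds along the chain from an amide-type nitrogen in a ring and an aromatic carbon. The measured steps at this place all stayed small, so the expected step of a 1.1-fold higher number from compound 3 to compound 4 (0.06 log units; within the scatter) is none beyond the scatter, though the entering group lies outside what has been tried here. Compound 4 is therefore estimated at 100 nM, with a range from 35 nM to 300 nM.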

Compound 4, half-maximal inhibitory concentration: 62 nM
Compound 4: the middle estimate sits 1.6-fold (0.21 log units) above what was measured; the range from low to high includes it.
By their numbers in this assay, from the lowest: compounds 1, 4, 3 and 2 (each within the scatter of the next, the first and the last beyond it).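

On a saturated chain carbon, four bonds along the chain from an amide-type nitrogen in a ring and an aromatic carbon, the six-membered (6-methoxypyrazin-2-yl)amino group does not separate from the thiophene-bearing groups, with a 1.1-fold higher number from compound 1 to compound 4 (0.02 log units; within the scatter) and a 1.4-fold lower number from compound 3 to compound 4 (0.15 log units; within the scatter) as the steps. The carbonyl-linked thiophene group now stands apart in a second step, with a 2.3-fold lower number from compound 2 to compound 4 (0.35 log units; beyond the scatter) also lying beyond the scatter. No measurement here offers an explanation for these steps.
Still open, on these data alone, is whether a carboxylic acid, a pyridine ring or a longer chain at this place would stay in this range. As far as these compounds go, the contribution of the methoxy group on the pyrazine ring also remains open.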